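Compound 1 to compound 3: a new side chain

The source may hold more compounds than are shown below. What is called first, only, known or untested is meant among the compounds shown, and "the series" means these compounds.

For the measured compounds named here, in an ADME assay on cells (Homo sapiens) for cytotoxicity, read by resazurin assay, with a stated time of 5 days (a lower number here means that less compound is tolerated, a higher number that more compound is tolerated), compound 1 `COc1ccc(-c2nc(CC(=O)c3cccc(Cl)c3)nc3ccsc23)cn1` gives 30000 nM, the only actual number so far. Compound 2 `COc1ccc(-c2nc(C(C)S(=O)(=O)c3cccc(Cl)c3)nc3ccsc23)cn1` reads > 50000 nM, which is a limit and not a number.

Compound 3 `COc1ccc(-c2nc(CSCc3cccc(Cl)c3)nc3ccsc23)cn1` keeps the core of compound 1 and differs on a saturated chain carbon bound to an aromatic carbon, with (3-chlorobenzyl)sulfanyl in place of (3-chlorophenyl)carbonyl ((3-chlorobenzyl)sulfanyl in place of (3-chlorophenyl)carbonyl on a saturated chain carbon bound to an aromatic carbon).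

Going by the values given here, no measured step covers this change, so the expectation rests on compound 1 at 30000 nM alone. No step beyond the usual scatter is expected in this assay, in either direction. The expected step is no change at the digits printed from compound 1 to compound 3 (within the scatter). For compound 3 the estimate is 30000 nM, with an expected range from 12000 nM to 60000 nM.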

Compound 3, half-maximal cytotoxic concentration: > 50000 nM
Compound 3 gave a limit, no number; the forecaster's own chance of this, stated with the estimate: 35%; middle value at least 1.6-fold (0.22 log units) away from the limit.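

In this assay, (3-chlorobenzyl)sulfanyl in place of (3-chlorophenyl)carbonyl on a saturated chain carbon bound to an aromatic carbon gives an at least 1.6-fold higher number from compound 1 to compound 3 (0.22 log units; that floor lies within the scatter). For the compounds shown here, this is the first one-place comparison at this position, and it gives no sign of lower tolerance with the new side chain, but compound 3 reads as a limit and not a number, so the full size of the step cannot be read. With this result the series reads mainly as limits: the limit of > 50000 nM in this assay, at which 2 of the 3 values shown sit.

As far as these compounds go, whether the sulfur or some other part of (3-chlorobenzyl)sulfanyl matters here remains open. From the compounds shown here alone, it is also open whether an amine, a carboxylic acid or a longer chain at this place would give a number in this assay rather than a limit.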